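This account rests on a few compounds, and the source may have more. Where it says the series, first, only, none or still open, it means among the compounds named here.

Compound 1 `C/C=C(\C)C(=O)O[C@H]1[C@H]2[C@@H]([C@@H](OC(C)=O)[C@@H](C)C(=O)[C@@]34C[C@H](C)[C@H](OC(C)=O)[C@]3(/C=C(\C)[C@H]1O)O4)C2(C)C`: > 100000 nM, a limit
Compound 2 `C/C=C(\C)C(=O)O[C@H]1[C@H]2[C@@H]([C@@H](OC(C)=O)[C@@H](C)C(=O)[C@@]34C[C@H](C)[C@H](OC(=O)/C(C)=C/C)[C@]3(/C=C(\C)[C@H]1O)O4)C2(C)C`: 26900 nM

Within the data shown here, in a functional assay on BV-2 cells (Mus musculus) for inhibition, read by Griess assay, with a stated time of 24 h (on this read-out higher numbers stand for weaker inhibition and lower numbers for stronger inhibition), compound 2 gives 26900 nM, the only actual number so far. For compound 1, > 100000 nM is a limit of the assay. Compound 3 `C/C=C(\C)C(=O)O[C@H]1[C@H]2[C@@H]([C@@H](OC(C)=O)[C@@H](C)C(=O)[C@@]34C[C@H](C)[C@H](OC(=O)c5ccccc5)[C@]3(/C=C(\C)[C@H]1O)O4)C2(C)C` differs from compound 2 as follows: phenyl in place of 1-methylprop-1-en-1-yl on a carbonyl carbon. Among the measured compounds shown here, the one measured step at such a carbon, an at least 3.7-fold lower number from compound 1 to compound 2 (0.57 log units; beyond the scatter), replaced methyl and starts from a limit, so it gives only weak guidance for this exchange. In this assay the expected change is small, perhaps slightly towards stronger inhibition: a 1.3-fold lower number from compound 2 to compound 3 (0.13 log units; within the scatter). For compound 3 the estimated value is 20000 nM, with an expected range of 6000 nM to 70000 nM.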

Compound 3, half-maximal inhibitory concentration: 14500 nM
The estimate for compound 3 lay 1.4-fold (0.14 log units) above the measured number; low and high end bracket the measured number.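

In this assay, the benzoyl and (1-methylprop-1-en-1-yl)carbonyl esters cannot be told apart, with a 1.9-fold lower number from compound 2 to compound 3 (0.27 log units; within the scatter). Phenyl in place of methyl on this carbonyl carbon gives an at least 6.8-fold lower number from compound 1 to compound 3 (0.83 log units; beyond the scatter), so a six-membered aromatic ring is tolerated here as well as the open-chain alkene. Compound 1 is a limit, so that step gives only a bound: the limit of > 100000 nM in this assay, at which 1 of the 3 values shown sits.

The compounds shown leave open whether a phenyl ring carrying an amine or a carboxylic acid, or a longer saturated chain on this carbonyl carbon, would shift the number beyond the scatter.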